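Swapping a Pyrimidine for a Carbamate at the Ring Nitrogen

The source may report more compounds than this note shows. Statements on the series, on what has been measured and on what is new or still open speak of the compounds shown alone.

Compound 1 `O=C(OC1CC1)N1CCc2cc(C3(C(=O)Nc4ccc(F)cc4)CCC3)ccc21` gives 1.4 nM in an assay on HeLa cells for inhibition of Indoleamine 2,3-dioxygenase 1 (Homo sapiens); a higher number here means a weaker inhibitor, a lower number a stronger inhibitor.
Compound 2 `O=C(Nc1ccc(Cl)cc1)C1(c2ccc3c(n2)CCN3c2ccccn2)CCC1` gives 2.3 nM in this assay.
Compound 3 `Cc1nccc(N2CCc3nc(C4(C(=O)Nc5ccc(Cl)cc5)CCC4)ccc32)n1` gives 12.5 nM in this assay.

Of these three, compound 3 is the weakest inhibitor in this assay; its gaps to compound 2 and to compound 1 both lie beyond the scatter. Compound 4 `O=C(OC1CC1)N1CCc2nc(C3(C(=O)Nc4ccc(Cl)cc4)CCC3)ccc21` differs from compound 3 at a single place: cyclopropyloxycarbonyl in place of 2-methylpyrimidin-4-yl on a nitrogen on an aromatic ring in a ring. Among the measured compounds shown here, the only measured step at that same nitrogen, a 5.4-fold higher number from compound 2 to compound 3 (0.74 log units; beyond the scatter), shows that changing this group can move the number well beyond the scatter. For the measured compounds named here, compound 1 carries the same cyclopropyloxycarbonyl group and gives 1.4 nM, the lowest number here, though no single-change step links it to compound 4. Compound 4 is therefore expected to show a 6.3-fold lower number from compound 3 to compound 4 (0.80 log units; beyond the scatter), a clear drop. The estimate for compound 4 is 2 nM, ranging from 0.7 nM to 6 nM.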

Compound 4, half-maximal inhibitory concentration: 2 nM
Compound 4: middle estimate and measured number agree at the digits printed; low and high end bracket the measured number.
By their numbers in this assay, from the lowest: compounds 1, 4 and 2 (each within the scatter of the next); then compound 3.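

In this assay, cyclopropyloxycarbonyl on this nitrogen gives a 6.3-fold lower number from compound 3 to compound 4 (0.80 log units; beyond the scatter) and thus shows that a group with no aromatic ring can take the place of 2-methylpyrimidin-4-yl. Set against pyridin-2-yl, the same group gives a 1.2-fold lower number from compound 2 to compound 4 (0.06 log units; within the scatter) and this lies within the scatter, so in this pair an aromatic ring on the nitrogen is not required for a low number. Still open, on these data alone, is how a group such as an amide or a longer carbon chain would behave on this nitrogen. Nothing measured here explains why these groups differ or match.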